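The source may hold more compounds than are shown below. What is called first, only, known or untested is meant among the compounds shown, and "the series" means these compounds.

Three compounds share one core, a ring bearing three hydroxyls and an amine, and differ only in the chain attached to that amine. Compound 1 `CCCCCN[C@@H]1C=C[C@H](O)[C@H](O)[C@H]1O` carries a plain pentyl chain; in an assay for inhibition of beta-galactosidase (Homo sapiens), read by fluorescence, with a stated time of 30 min, at pH 4.5 (on this read-out lower numbers stand for stronger inhibition and higher numbers for weaker inhibition), compound 1 gives 19000 nM. Compound 3 `O[C@@H]1[C@@H](O)[C@H](NCC2CCCCC2)C=C[C@@H]1O` carries a cyclohexylmethyl chain, and in this assay compound 3 gives 60000 nM. Compound 2 `OCCCN[C@@H]1C=C[C@H](O)[C@H](O)[C@H]1O` carries a 3-hydroxypropyl chain. In this assay compound 2 reaches only a limit, > 1000000 nM, so no number is known for it. That limit is the limit of > 1000000 nM in this assay, at which 1 of the 3 values shown sits, and compound 2 therefore stands as the weakest of the three shown. Among the compounds with values here, the one measured step that touches this chain is an at least 52-fold higher number from compound 1 to compound 2 (1.72 log units; beyond the scatter).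

Compound 4 `CC(C)CCN[C@@H]1C=C[C@H](O)[C@H](O)[C@H]1O` has not been measured. It differs from compound 2 by isopropyl in place of hydroxymethyl on a saturated chain carbon, two bonds along the chain from an amine nitrogen, so the chain becomes an isopentyl, a branched relative of the pentyl chain of compound 1. Within the data shown here, the step from compound 1 to compound 2 is the only measured step that bears on this change, and the change in compound 4 largely runs it backwards, removing the hydroxy and restoring a hydrocarbon chain. A large drop in the number is therefore expected, an at least 40-fold lower number from compound 2 to compound 4 (1.60 log units; beyond the scatter). Compound 4 is estimated at 25000 nM, with a range from 8000 nM to 90000 nM.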

Compound 4, half-maximal inhibitory concentration: 28000 nM
For compound 4 the middle estimate is 1.1-fold (0.05 log units) below the measured one; measured number inside the range.
By their numbers in this assay, from the lowest: compounds 1 and 4 (each within the scatter of the next); then compound 3. At a limit, above all of these: compound 2.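

Set side by side in this assay, the pentyl chain and the isopentyl chain give a 1.5-fold higher number from compound 1 to compound 4 (0.17 log units; within the scatter), so branching at this place, two bonds along the chain from the amine nitrogen, makes no difference that this read-out can detect. Within the data shown here, the earlier compounds offered only one comparison with the 3-hydroxypropyl chain; a second hydrocarbon chain now gives the same kind of result, with an at least 35-fold lower number from compound 2 to compound 4 (1.55 log units; beyond the scatter), so the large gap does not depend on one particular chain shape. The size of this step is only a bound, since compound 2 stands at a limit and has no exact number: the limit of > 1000000 nM in this assay, at which 1 of the 4 values shown sits.

The 3-hydroxypropyl chain differs from the pentyl and isopentyl chains both in carrying a hydroxy and in its length, so these compounds do not show which of the two differences matters, and a plain propyl chain or a 5-hydroxypentyl chain would be needed to separate them. Going by these compounds, how an amine or a carboxylic acid in place of the hydroxy would read, and how far a longer chain would carry the same result, also remains open.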